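Thiazolyl to methylphenyl swap on the piperidine core

A few compounds are considered here, and "the series" means these few. Any claim that something is new, unique, unknown or untested is made for them only; others in the source may bear on it.

Compound 1 `Cc1cccc(NC(=O)CN2CCC(c3nccs3)CC2)c1` holds the lowest number of the two measured compounds: in a functional assay on HEK293 cells for agonist activity at D(4) dopamine receptor (Homo sapiens), read by FLIPR (a lower number here means that less compound is needed, a higher number that more compound is needed for the effect), compound 1 gives 1 nM. Going by the values given here, compound 2 `O=C(NCN1CCC(c2cccc[n+]2[O-])CC1)c1ccc(F)c(Cl)c1` in this assay gives 63 nM, a much higher number, though the two structures differ in several places at once and no single step between them can be read. Compound 3 `Cc1cccc(NC(=O)CN2CCC(c3ccccc3C)CC2)c1` is not yet measured; it differs from compound 1 by 2-methylphenyl in place of 1,3-thiazol-2-yl on a saturated ring carbon. Among the compounds with values here, with no measured step available for this change, a modest rise in the number is expected, the estimated step from compound 1 to compound 3 being a 5.0-fold higher number from compound 1 to compound 3 (0.70 log units; beyond the scatter). Compound 3 is accordingly estimated at 5 nM, within 1.5 nM to 20 nM.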

Compound 3, half-maximal effective concentration: 340 nM
The estimate for compound 3 lay 68-fold (1.83 log units) below the measured number; measured number outside the range, above it.
By their numbers in this assay, from the lowest: compound 1; then compound 2; then compound 3.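

In this assay, the saturated ring carbon of the shared core proves highly sensitive to the group it carries: 2-methylphenyl in place of 1,3-thiazol-2-yl gives a 340-fold higher number from compound 1 to compound 3 (2.53 log units; beyond the scatter). Going by these compounds alone, this is the only single change readable so far, and it replaces a five-membered aromatic ring with 2 hetero atoms by a six-membered aromatic ring of carbon only. No measured evidence explains the size of this step.

Open, from the compounds shown here alone, is whether phenyl without the methyl, or 1,3-oxazol-2-yl, on this carbon stands nearer compound 1 or compound 3. The contributions of the ring change and the methyl therefore remain unseparated.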